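This account rests on a few compounds, and the source may have more. Where it says the series, first, only, none or still open, it means among the compounds named here.

Compound 1 `C[C@@H](Cn1c(=O)[nH]/c(=N\c2ccc(Oc3nccs3)cc2)n(Cc2ccc(Cl)cc2)c1=O)C(=O)O` stands highest of the two values shown in an ADME assay on the whole organism (plasma, Rattus norvegicus) for protein binding, using cassette dosing, at a dose of 1 mg/kg (on this read-out higher numbers stand for a larger free fraction and lower numbers for a smaller free fraction), and compound 1 gives 0.006. Compound 2 `CC(C)Oc1ccc(/N=c2\[nH]c(=O)n(C[C@@H](O)CO)c(=O)n2Cc2ccc(Cl)cc2)cc1Cl` gives 0.001 in this assay, a gap beyond the usual scatter. Compound 3 `C[C@@H](Cn1c(=O)[nH]/c(=N\c2ccc(Oc3ccsn3)cc2)n(Cc2ccc(Cl)cc2)c1=O)C(=O)O` differs from compound 1 in one place: 1,2-thiazol-3-yl in place of 1,3-thiazol-2-yl on an oxygen on an aromatic ring. The two hold the same atoms, joined differently. Among the measured compounds shown here, no measured pair shows this change, so compound 3 is expected to sit close to compound 1, with a step of no change at the digits printed from compound 1 to compound 3 (within the scatter) that is expected to stay within the scatter in either direction. Compound 3 is therefore estimated at 0.006, between 0.003 and 0.012.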

Compound 3, unbound fraction: 0.012
Compound 3: the middle estimate sits 2.0-fold (0.30 log units) below what was measured; measured number inside the range.
By their numbers in this assay, from the lowest: compound 2; then compounds 1 and 3 (each within the scatter of the next).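

Among the compounds shown here, with 1,2-thiazol-3-yl in place of 1,3-thiazol-2-yl on an oxygen on an aromatic ring, this assay gives a 2.0-fold higher number from compound 1 to compound 3 (0.30 log units; within the scatter) and so offers the first direct reading at this position. Moving the ring atoms of the thiazole, with the same atoms kept, leaves the unbound fraction within the scatter here. Nothing at hand offers an explanation for this step. Going by these compounds, whether this position keeps the same reading with a phenyl ring, a pyridine or a simple methyl group in place of the thiazole remains open.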